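The source may report more compounds than this note shows. Statements on the series, on what has been measured and on what is new or still open speak of the compounds shown alone.

Compound 1 `Oc1cccc2[nH]c(-c3ccc(-c4ccc(-c5ccccc5)cc4)cc3)nc12` gives 9680 nM in a functional assay on DWD cells (Homo sapiens) for inhibition, read by sulforhodamine B assay; on this read-out lower numbers stand for stronger inhibition of growth and higher numbers for weaker inhibition of growth. Compound 2 `Oc1cccc2[nH]c(-c3ccc(-c4ccc(-c5ccc(F)cc5)cc4)cc3)nc12` differs from it by fluoro in place of hydrogen on an aromatic carbon; in this assay compound 2 gives 22200 nM, so the change brought a 2.3-fold higher number from compound 1 to compound 2 (0.36 log units; beyond the scatter). Compound 3 `Cc1ccc2[nH]c(-c3ccc(-c4ccc(-c5ccccc5)cc4)cc3)nc2c1` carries a different core; how the two cores differ is not broken down here. In this assay compound 3 gives 28300 nM. Compound 4 `Cc1ccc2[nH]c(-c3ccc(-c4ccc(-c5ccc(F)cc5)cc4)cc3)nc2c1` is not yet measured and differs from compound 3 by fluoro in place of hydrogen on an aromatic carbon, the same change as from compound 1 to compound 2, at the same place. For compound 4 a step of about the same size is expected, a 1.9-fold higher number from compound 3 to compound 4 (0.29 log units; within the scatter), resting on the single earlier occurrence a 2.3-fold higher number from compound 1 to compound 2 (0.36 log units; beyond the scatter). Because compound 3 already stands at 28300 nM, compound 4 is estimated at 55000 nM, with a likely range from 25000 nM to 120000 nM.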

Compound 4, concentration for 50% growth inhibition: 33100 nM
Beside the measured number, compound 4's estimate is 1.7-fold (0.22 log units) above it, within the range that was stated.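

On the core of the methyl-bearing pair, phenyl to 4-fluorophenyl gives a 1.2-fold higher number from compound 3 to compound 4 (0.07 log units; within the scatter) in this assay. Set beside the earlier step, the two cannot be told apart: the same change on two cores in this assay, a 2.3-fold higher number (0.36 log units; beyond the scatter) from compound 1 to compound 2 and a 1.2-fold higher number (0.07 log units; within the scatter) from compound 3 to compound 4, 2.0-fold (0.29 log units) apart, within the scatter of two such steps. The change therefore carries from one core to the other with no detectable difference in size, but this rests on a single pair per core, and since the new step lies within the scatter, it does not show that fluoro raises the number on every core in the series.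

Still open, on these data alone, is how other groups at this same place, such as chloro, methoxy, an amine or a carboxylic acid, would behave on either core. Whether any of them would lower the number on both cores alike is also unsettled.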